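Swapping trifluoromethyl for iodo on the aniline ring

The source may hold more compounds than are shown below. What is called first, only, known or untested is meant among the compounds shown, and "the series" means these compounds.

Measured in a functional assay on MCF7 cells (Homo sapiens) for inhibition, read by sulforhodamine B assay; a higher number here means a weaker inhibitor, a lower number a stronger inhibitor:
- Compound 1 `CCc1ccc(NC2=CC(=O)c3nc4n(c3C2=O)[C@H]2OC[C@@H](O)[C@H]2OC4)cc1`: 960 nM
- Compound 2 `O=C1C=C(Nc2ccc(Br)cc2)C(=O)c2c1nc1n2[C@H]2OC[C@@H](O)[C@H]2OC1`: 2580 nM
- Compound 3 `O=C1C=C(Nc2ccc(C(F)(F)F)cc2)C(=O)c2c1nc1n2[C@H]2OC[C@@H](O)[C@H]2OC1`: > 4000 nM

Compound 3 gives no number, only a limit of the assay, > 4000 nM. Compound 4 `O=C1C=C(Nc2ccc(I)cc2)C(=O)c2c1nc1n2[C@H]2OC[C@@H](O)[C@H]2OC1` carries iodo in place of trifluoromethyl on an aromatic carbon, para to a large group (iodo in place of trifluoromethyl on an aromatic carbon). Two steps start from the ethyl of compound 1: a 2.7-fold higher number from compound 1 to compound 2 (0.43 log units; beyond the scatter) and an at least 4.1-fold higher number from compound 1 to compound 3 (0.61 log units; beyond the scatter). The nearest evidence is an at least 1.5-fold higher number from compound 2 to compound 3 (0.19 log units; that floor lies within the scatter), and compound 2, with bromo, is taken as the closest measured model for iodo. The step of an at least 1.6-fold lower number from compound 3 to compound 4 (0.20 log units; that floor lies within the scatter) is therefore expected to be small, towards a lower number, and may not clear the scatter. In this assay the estimate for compound 4 is 2500 nM, with an expected range of 1200 nM to 4500 nM.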

Compound 4, half-maximal inhibitory concentration: 2230 nM
For compound 4 the middle estimate is 1.1-fold (0.05 log units) above the measured one, within the range that was stated.
By their numbers in this assay, from the lowest: compound 1; then compounds 4 and 2 (each within the scatter of the next). At a limit, above all of these: compound 3.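

In this assay, iodo in place of bromo at this position gives no difference that can be told apart, with a 1.2-fold lower number from compound 2 to compound 4 (0.06 log units; within the scatter). Iodo in place of ethyl gives a 2.3-fold higher number from compound 1 to compound 4 (0.37 log units; beyond the scatter), in the same direction as bromo, while iodo in place of trifluoromethyl gives an at least 1.7-fold lower number from compound 3 to compound 4 (0.25 log units; that floor lies within the scatter), which is only a floor. Compound 3 remains a limit of the assay and not a number: the limit of > 4000 nM in this assay, at which 1 of the 4 values shown sits.

The compounds shown leave open how a methoxy group or an amine would read at this place, and whether a longer chain than ethyl would give a number lower than that of compound 1. They also leave open how far compound 3 truly lies from compound 4.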